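The compounds below may be only part of what the source reports. "The series", "measured", "known", "first", "only" and "open" are said of these compounds alone.

Measured in an ADME assay on L6 cells (Rattus norvegicus) for cytotoxicity; a higher number here means a weaker inhibitor, a lower number a stronger inhibitor:
Compound 1 `OC1CC2(N3CCCC3)CC(c3ccccc3)C1C(c1ccccc1)C2`: 26800 nM
Compound 2 `OC1CC2(N3CCCCC3)CC(c3ccccc3)C1C(c1ccccc1)C2`: 37300 nM
Compound 3 `COc1ccc(C2CC3(N(C)C)CC(=O)C2C(c2ccc(OC)cc2)C3)cc1`: 52400 nM

These three values all lie within the usual scatter of one another, so compound 3 does not stand apart from compound 1 or compound 2. Compound 4 `COc1ccc(C2CC3(N4CCCC4)CC(=O)C2C(c2ccc(OC)cc2)C3)cc1` keeps the core of compound 3 and makes one change: pyrrolidin-1-yl in place of dimethylamino on a saturated ring carbon. For the measured compounds named here, only one measured step bears on this change, a 1.4-fold higher number from compound 1 to compound 2 (0.14 log units; within the scatter). That step swaps one ring group for another on a different core, and it stays within the scatter, so no step beyond the scatter is expected in this assay. The expected step is small: a 1.2-fold lower number from compound 3 to compound 4 (0.09 log units; within the scatter). The estimate for compound 4 is 43000 nM, with an expected range of 20000 nM to 90000 nM.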

Compound 4, half-maximal inhibitory concentration: 41900 nM
Compound 4: the middle estimate sits 1.0-fold (0.01 log units) above what was measured; low and high end bracket the measured number.
By their numbers in this assay, from the lowest: compounds 1, 2, 4 and 3 (each within the scatter of the next).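

On the core of compound 3, replacing the open dimethylamino group with the ring of pyrrolidin-1-yl gives a 1.3-fold lower number from compound 3 to compound 4 (0.10 log units; within the scatter) in this assay. So at this saturated ring carbon, a change from an open group to a ring shifts the number no more than the scatter allows, whereas the earlier step only swapped one ring for another on a different core. No measurement here offers an explanation for this result. As far as these compounds go, how a morpholin-4-yl group or a primary amine would behave at this carbon stays open.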